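Amide substituent swap on a weakly antiproliferative quinazolinone-type scaffold

The source may report more compounds than this note shows. Statements on the series, on what has been measured and on what is new or still open speak of the compounds shown alone.

Measured so far:
- compound 1, `Cc1noc(C)c1-c1nn(Cc2ccc(C(=O)NC3CC(C)(C)N([O])C(C)(C)C3)cc2)c(=O)c2ccccc12`: 83500 nM
- compound 2, `Cn1cc(-c2nn(Cc3ccc(C(=O)N4CCCCC4)cc3)c(=O)c3ccccc23)cn1`: 65500 nM

Both compounds were tested in a functional assay on HeLa cells (Homo sapiens) for antiproliferative activity, read by MTT assay, with a stated time of 72 h; on this read-out lower numbers stand for stronger inhibition and higher numbers for weaker inhibition. Compound 1 gives 83500 nM, the higher of the two numbers, while compound 2 gives 65500 nM; the two values lie within the usual scatter of repeated measurements, so no difference between them can be claimed. Both compounds are weak in this assay.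

Compound 3, `Cc1noc(C)c1-c1nn(Cc2ccc(C(=O)NC3CCN(C)CC3)cc2)c(=O)c2ccccc12`, has not yet been measured. It differs from compound 1 in one place: a group of 7 heavy atoms (6 carbon, 1 nitrogen; one six-membered non-aromatic ring with 1 hetero atom) in place of a group of 11 heavy atoms (9 carbon, 1 nitrogen, 1 oxygen; one six-membered non-aromatic ring with 1 hetero atom), on an amide-type nitrogen. The rest of the molecule, including the shared core and the benzamide linker, is unchanged.

Within the data shown here, no step between two measured compounds that share this kind of change is available, so the expectation rests only on the two weak values already in hand. With both measured compounds sitting at a similar, weak level, the expected step from compound 1 to compound 3 is a 1.3-fold lower number from compound 1 to compound 3 (0.11 log units; within the scatter), that is, no change beyond the scatter. Compound 3 is therefore estimated at 65000 nM, with a range from 20000 nM to 200000 nM.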

Compound 3, half-maximal inhibitory concentration: > 100000 nM
Compound 3 gave a limit, no number; the forecaster's own chance of this, stated with the estimate: 25%; middle value at least 1.5-fold (0.18 log units) away from the limit.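

In this assay, putting 1-methylpiperidin-4-yl in place of the larger ring group on the amide-type nitrogen gives an at least 1.1-fold higher number from compound 1 to compound 3 (0.07 log units; that floor lies within the scatter), so this change brings no gain in inhibition at this position. Compound 3 gives > 100000 nM, which is a limit of the assay and not a number. The step therefore has a floor but no measured size, and the change could be anywhere from negligible to large, because the value of compound 3 rests on this boundary: the limit of > 100000 nM in this assay, at which 1 of the 3 values shown sits.

The compounds shown leave open whether another group on this amide-type nitrogen, such as a morpholine ring or a longer chain ending in a carboxylic acid, would give a clearly lower number than the weak level seen so far. They also leave open what the shared core and its other ring substituent contribute, since compound 2 differs from compound 1 and from compound 3 in more than one place and so offers no clean comparison with either.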